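Carbamoyl to Carboxy: Expecting a Weak Binder

The source may hold more compounds than are shown below. What is called first, only, known or untested is meant among the compounds shown, and "the series" means these compounds.

Three compounds have been measured in an assay for inhibition of Fatty-acid amide hydrolase 1 (Rattus norvegicus); on this read-out lower numbers stand for stronger inhibition and higher numbers for weaker inhibition:

Compound 1, `NC(=O)c1cccc(-c2cnc(C(O)CCc3ccc(-c4ccccc4)cc3)o2)n1`: 20000 nM
Compound 2, `O=C(O)c1ccc(-c2cnc(CCCc3ccc(-c4ccccc4)cc3)o2)nc1`: 20000 nM
Compound 3, `NC(=O)c1ccc(-c2cnc(C(O)CCc3ccc(-c4ccccc4)cc3)o2)nc1`: > 1000 nM

The value shown for compound 3 is a limit of the assay, not a number, as noted in the limit of > 1000 nM in this assay, at which 1 of the 3 values shown sits. Compound 3 therefore stands at the weak end of what this assay reports, and the step that the limit leaves unreadable from compound 1 to compound 3 cannot be read in size for the same reason. Compound 2 carries a carboxy group on a shared core and gives 20000 nM in this assay, also at the weak end.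

Compound 4, `O=C(O)c1ccc(-c2cnc(C(O)CCc3ccc(-c4ccccc4)cc3)o2)nc1`, has not yet been measured. It differs from compound 3 in one place: hydroxy in place of amino on a carbonyl carbon. For the measured compounds named here, no measured step tells what swapping amino for hydroxy on this carbonyl carbon does here. Going by the values given here, the only guidance is that both the carboxy-bearing compound 2 and the carbamoyl-bearing compound 3 sit at weak inhibition, so the step that the limit leaves unreadable from compound 3 to compound 4 is expected to be small and is most likely to stay within the scatter. For compound 4 the expected result in this assay is 20000 nM, with a range from 3000 nM to 60000 nM, and there is a fair chance that only a limit is reported.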

Compound 4, inhibition constant: 10000 nM
Estimate against measurement, compound 4: 2.0-fold (0.30 log units) above, and the stated range covers the measured number.
By their numbers in this assay, from the lowest: compounds 4, 1 and 2 (each within the scatter of the next).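

In this assay, hydroxy in place of hydrogen on the saturated chain carbon gives a 2.0-fold lower number from compound 2 to compound 4 (0.30 log units; within the scatter), so with the 5-carboxypyridin-2-yl group in place, this chain hydroxy makes no difference that can be told from the scatter. Putting 5-carboxypyridin-2-yl in place of 6-carbamoylpyridin-2-yl gives a 2.0-fold lower number from compound 1 to compound 4 (0.30 log units; within the scatter), so this exchange on the aromatic carbon, which changes both the group and its place, also shows no real shift. Compound 3 carries a limit and not a number, so the steps that start or end at it cannot be read in size: the limit of > 1000 nM in this assay, at which 1 of the 4 values shown sits.

For the compounds shown here, what hydroxy in place of amino on this carbonyl carbon does on its own therefore stays open, as the one direct comparison for that change has no readable size. Also open, on these data alone, is whether another group on the pyridine carbon that holds the carbonyl, such as a methyl ester or an amine, or a longer chain in place of the present one, would move the number in this assay beyond the scatter.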